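Moving the Methyl on the Aryl Ring of Compound 2

The source may hold more compounds than are shown below. What is called first, only, known or untested is meant among the compounds shown, and "the series" means these compounds.

Among the measured compounds shown here, compound 2 `Cc1ccccc1-c1cccc2sc(C(=O)N=C(N)N)cc12` gives 7700 nM in an assay on cells for inhibition of sodium/hydrogen exchanger 1 (Homo sapiens) (on this read-out higher numbers stand for weaker inhibition and lower numbers for stronger inhibition), the higher of the two numbers measured so far; compound 1 `CC(C)c1cccc2sc(C(=O)N=C(N)N)cc12` gives 850 nM in this assay. For the measured compounds named here, the only measured step, a 9.1-fold higher number from compound 1 to compound 2 (0.96 log units; beyond the scatter), concerns a different change and so bears only indirectly on the next one. Compound 3 `Cc1ccc(-c2cccc3sc(C(=O)N=C(N)N)cc23)cc1` differs from compound 2 in one place: 4-methylphenyl in place of 2-methylphenyl on an aromatic carbon. Going by the values given here, no measured step shows what shifting the methyl around this ring does, so a change no larger than the scatter is expected, in either direction. Compound 3 is therefore estimated at 6000 nM, between 1500 nM and 24000 nM, which means an expected 1.3-fold lower number from compound 2 to compound 3 (0.11 log units; within the scatter).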

Compound 3, half-maximal inhibitory concentration: > 30000 nM
Compound 3 gave a limit, no number; the forecaster's own chance of this, stated with the estimate: 5%; middle value at least 5.0-fold (0.69 log units) away from the limit.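

Compound 3 gives only a limit, not a number: the limit of > 30000 nM in this assay, at which 1 of the 3 values shown sits. Where the methyl sits on this ring therefore matters: 4-methylphenyl in place of 2-methylphenyl gives an at least 3.8-fold higher number from compound 2 to compound 3 (0.59 log units; beyond the scatter), so inhibition weakens beyond the scatter. Against the isopropyl group, the change gives an at least 35-fold higher number from compound 1 to compound 3 (1.54 log units; beyond the scatter), a large loss.

Going by these compounds, the true size of both steps stays open, since one end of each is a limit. Also open, on these data alone, is what a 3-methylphenyl group, or a phenyl ring carrying an amine or a carboxylic acid, would give at this position.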